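Swapping one five-membered ring for another on a shared core

The compounds below may be only part of what the source reports. "The series", "measured", "known", "first", "only" and "open" are said of these compounds alone.

Measured compounds:
compound 1 `Cc1nc(-c2ccccc2NCC2=NCCN2)cs1` — in a functional assay for activation of Alpha-1D adrenergic receptor (Homo sapiens) (on this read-out lower numbers stand for an effect already at smaller amounts and higher numbers for an effect only at larger amounts of compound), compound 1 gives < 5020 nM, a limit of the assay rather than a number.
compound 2 `Cc1nc(-c2ccccc2NCC2=NCCN2)co1` — in this assay compound 2 gives < 5020 nM, likewise only a limit.

Both compounds share the same core and differ only in one five-membered ring. Among the measured compounds shown here, the single measured step, a step that the two limits leave unreadable from compound 1 to compound 2, cannot be read, since both of its ends sit at the limit of < 5020 nM in this assay, at which 2 of the 2 values shown sit. Compound 2 therefore stands at the limit and nowhere more precise. Compound 3 `c1ccc(-c2cnoc2)c(NCC2=NCCN2)c1` differs from compound 2 by 1,2-oxazol-4-yl in place of 2-methyl-1,3-oxazol-4-yl on an aromatic carbon. For the measured compounds named here, no measured step bears on this change, and the one step that exists gives no size to lean on. The step from compound 2 to compound 3 is thus expected to be small, a step that the limit leaves unreadable from compound 2 to compound 3, with compound 3 expected to remain in the same region as its parent. For compound 3 the estimate in this assay is 2000 nM, with a range from 300 nM to 8000 nM.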

Compound 3, half-maximal effective concentration: < 100000 nM
Compound 3 gave a limit, no number; the forecaster's own chance of this, stated with the estimate: 50%; the middle value lies beyond the limit too.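

In this assay, among the compounds shown here, compound 1, compound 2 and compound 3 each give only a limit, not a number, so no step among them can be read. The compounds shown leave open whether changing the five-membered ring on the shared core shifts the result in this assay at all, and in which direction.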